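The source may report more compounds than this note shows. Statements on the series, on what has been measured and on what is new or still open speak of the compounds shown alone.

Going by the values given here, compound 3 `Cc1nc(S(C)(=O)=O)ccc1Oc1ncnc(OC2CCN(C(=O)SC(C)C)CC2)c1F` gives the lowest number of the three measured members: in a functional assay on isolated protein for inhibition of Glucose-dependent insulinotropic receptor (Rattus norvegicus), read by HTRF and cAMP accumulation (on this read-out higher numbers stand for an effect only at larger amounts of compound and lower numbers for an effect already at smaller amounts), compound 3 gives 41.3 nM, while compound 2 `CCC1(OC(=O)N2CCC(Oc3ncnc(Oc4ccc(S(C)(=O)=O)nc4C)c3F)CC2)CC1` gives 333 nM and compound 1 `Cc1nc(S(C)(=O)=O)ccc1Oc1ncnc(OC2CCN(C(=O)O[C@H](C)CF)CC2)c1F` gives 1520 nM. Both gaps run beyond the scatter, an 8.1-fold lower number from compound 2 to compound 3 (0.91 log units; beyond the scatter) and a 37-fold lower number from compound 1 to compound 3 (1.57 log units; beyond the scatter); the smaller step between the two carbamates is a 4.6-fold lower number from compound 1 to compound 2 (0.66 log units; beyond the scatter).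

Compound 4 `Cc1nc(S(C)(=O)=O)ccc1Oc1ncnc(OC2CCN(C(=O)C(C)(C)F)CC2)c1F` keeps the shared core and changes only the acyl part: 1-fluoro-1-methylethyl in place of isopropylsulfanyl on a carbonyl carbon.

Bearing on this step are the two changes already seen on the carbonyl carbon, both of which moved the number strongly downward when the isopropylsulfanyl group entered. Among the compounds with values here, the present step goes the other way, taking that group out again, but what enters is not a carbamate-type oxygen-linked group but 1-fluoro-1-methylethyl, for which no measured analogue exists. The expectation is therefore a step upward from compound 3 to compound 4, a 3.6-fold higher number from compound 3 to compound 4 (0.56 log units; beyond the scatter), sized below the two measured steps and with wide uncertainty. Compound 4 is estimated at 150 nM in this assay, with a range from 30 nM to 800 nM.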

Compound 4, half-maximal effective concentration: 296 nM
Estimate against measurement, compound 4: 2.0-fold (0.30 log units) below; the range from low to high includes it.
By their numbers in this assay, from the lowest: compound 3; then compounds 4 and 2 (each within the scatter of the next); then compound 1.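

In this assay, a group joined through carbon, 1-fluoro-1-methylethyl, now stands on the carbonyl carbon, and it does not keep the low number seen with isopropylsulfanyl: a 7.2-fold higher number from compound 3 to compound 4 (0.86 log units; beyond the scatter). Against the two oxygen-linked groups it gives a split result, with a 1.1-fold lower number from compound 2 to compound 4 (0.05 log units; within the scatter) and a 5.1-fold lower number from compound 1 to compound 4 (0.71 log units; beyond the scatter), so among these four compounds isopropylsulfanyl alone stands apart at the low end, and the presence of fluorine in a group does not by itself set the number. Nothing at hand explains these differences.

Still open, going by these compounds, is whether the low number follows the sulfur link itself or the isopropyl group carried on it. Isopropoxy, isopropylamino, ethylsulfanyl or tert-butylsulfanyl on the same carbonyl carbon would bear on that question.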